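Compound 2 to compound 4: swapping carbamoyl for pyrazolyl

A few compounds are considered here, and "the series" means these few. Any claim that something is new, unique, unknown or untested is made for them only; others in the source may bear on it.

Measured in a physicochemical assay for solubility, in phosphate buffer, with a stated time of 1 h, at pH 7.4 (on this read-out lower numbers stand for lower solubility and higher numbers for higher solubility), so far:
- compound 1 `NC(=O)c1ccc(NC(=O)c2ccccc2)cc1` gives 13 ug/mL
- compound 2 `NC(=O)c1ccc(N2CCc3ccccc3C2=O)cc1` gives 132 ug/mL
- compound 3 `O=C(Nc1cnc(-c2cc[nH]n2)nc1)c1ccccc1` gives 82 ug/mL

Compound 2 stands beyond the scatter above compound 1 and within the scatter of compound 3. Compound 4 `O=C1c2ccccc2CCN1c1ccc(-c2cc[nH]n2)cc1` has 1H-pyrazol-3-yl in place of carbamoyl on an aromatic carbon as its change from compound 2. Going by the values given here, no measured step isolates this change. Compound 3 also carries 1H-pyrazol-3-yl on a different core and gives 82 ug/mL in the same read-out, so a moderate fall rather than a collapse is expected. The expected change, beyond the scatter, is a 3.8-fold lower number from compound 2 to compound 4 (0.58 log units; beyond the scatter) in this assay as a working figure. For compound 4 the estimated value is 35 ug/mL with 10 ug/mL to 110 ug/mL as its expected range.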

Compound 4, solubility: 94 ug/mL
Compound 4: middle estimate off by 2.7-fold (0.43 log units), on the low side, within the range that was stated.
By their numbers in this assay, from the lowest: compound 1; then compounds 3, 4 and 2 (each within the scatter of the next).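

In this assay, 1H-pyrazol-3-yl in place of carbamoyl on an aromatic carbon, para to a large group, gives a 1.4-fold lower number from compound 2 to compound 4 (0.15 log units; within the scatter) and so lies within the scatter. On this core the read-out does not separate the two groups, although the entering group has 5 heavy atoms and a ring and the leaving group has 3 heavy atoms and no ring. No measurement available here accounts for this step. As far as these compounds go, whether an amine or a carboxylic acid on this aromatic carbon would also stay within the scatter of compound 2 remains open. So does the outcome of the same swap on the core of compound 1.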